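The source may report more compounds than this note shows. Statements on the series, on what has been measured and on what is new or still open speak of the compounds shown alone.

Measured so far:
Compound 1 `CN(C)C(=O)c1cc2cnc(Nc3ccc(NC(=O)C4(C(=O)Nc5ccc(Cl)cc5)CC4)cc3)nc2n1C1CCCC1`: 88.6%
Compound 2 `Cc1ccc(NC(=O)C2(C(=O)Nc3ccc(Nc4ncc5cc(C(=O)N(C)C)n(C6CCCC6)c5n4)cc3)CC2)cc1`: 84.5%

For the measured compounds named here, in a functional assay on NCI-H1299 cells (Homo sapiens) for inhibition, read by CCK-8 assay, with a stated time of 72 h, tested at 10 uM (on this read-out higher numbers stand for more inhibition of growth at the one concentration tested and lower numbers for less inhibition of growth), compound 2, at 84.5%, stands within the scatter of compound 1, the only other measured compound, so the two cannot be ranked. The next compound, compound 3 `CN(C)C(=O)c1cc2cnc(Nc3ccc(NC(=O)C4(C(=O)Nc5cccc(Br)c5)CC4)cc3)nc2n1C1CCCC1`, differs from compound 2 as follows: 3-bromophenyl in place of 4-methylphenyl on an amide-type nitrogen. Going by the values given here, the one measured step that bears on this is a number 4.1 percentage points lower from compound 1 to compound 2 (within the scatter), a change of methyl in place of chloro on an aromatic carbon. Among the compounds with values here, it is a single step, and no measured compound carries 3-bromophenyl, so the evidence is thin. Within the data shown here, with only that small step to go on, no change beyond the scatter is expected in this assay. The expected shift is a number 0.5 percentage points lower from compound 2 to compound 3 (within the scatter), which is estimated to be negligible. For compound 3 the estimated value is 84%, with an expected range of 71% to 94%.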

Compound 3, percent growth inhibition at one concentration: 77.5%
Compound 3: middle estimate off by 6.5 percentage points, on the high side, and the stated range covers the measured number.
By their numbers in this assay, from the lowest: compounds 3, 2 and 1 (each within the scatter of the next, the first and the last beyond it).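

In this assay, the aryl group on the amide-type nitrogen now gives its first step beyond the scatter: a number 11.1 percentage points lower from compound 1 to compound 3 (beyond the scatter), for 3-bromophenyl in place of 4-chlorophenyl. The same group in place of 4-methylphenyl gives a number 7 percentage points lower from compound 2 to compound 3 (within the scatter), so this position tolerates all three groups with at most a modest loss, and carrying a halogen does not by itself keep the number at the level of compound 1. These two aryl groups differ in both the halogen and its ring position, so the step cannot be assigned to either, and nothing shown accounts for it. Open, going by these compounds, is how 4-bromophenyl or 3-chlorophenyl would read, since either would separate the halogen from its ring position. Also open, on these data alone, is whether an unsubstituted phenyl or a pyridine ring would hold the number at this nitrogen.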